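The source may report more compounds than this note shows. Statements on the series, on what has been measured and on what is new or still open speak of the compounds shown alone.

In a functional assay on DA-3 cells for cytotoxicity against DA-3 cell line (Mus musculus), read by MTT assay (a lower number here means a stronger inhibitor, a higher number a weaker inhibitor), compound 1 (`CC(=O)O[C@@H]1OC(=O)[C@](C)(C(C)=O)[C@@H]1C`) gives 7000 nM. Compound 2 (`CC(=O)O[C@@H]1OC(=O)[C@](C)(C(=O)CBr)[C@@H]1C`) gives 4000 nM, and the gap is small: a 1.8-fold lower number from compound 1 to compound 2 (0.24 log units; within the scatter). Compound 3 (`CC(=O)O[C@@H]1OC(=O)[C@](C)(C(C)=O)[C@@H]1C(C)C`) gives > 50000 nM, which is a limit of the assay and not a number. Isopropyl in place of methyl on a saturated ring carbon accounts for the structural difference in the second measured step, an at least 7.1-fold higher number from compound 1 to compound 3 (0.85 log units; beyond the scatter).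

Compound 4 (`CC(=O)O[C@@H]1OC(=O)[C@@](C)(C(C)=O)[C@@H]1C`) keeps the atoms and bonds of compound 1: the two compounds have the same atoms and bonds and differ only in configuration as drawn: 1 of 3 stereo elements differ; a stereocentre at a saturated ring carbon is drawn S in compound 1 and R in compound 4. Neither measured step changes configuration, so neither gives the size of this change directly. The nearest guide is compound 3, where a change on a saturated ring carbon gave an at least 7.1-fold higher number from compound 1 to compound 3 (0.85 log units; beyond the scatter), while the chain change in compound 2 gave a 1.8-fold lower number from compound 1 to compound 2 (0.24 log units; within the scatter). A modest move in this assay towards a higher number is therefore expected, though a result within the scatter remains possible. The expected step is a 1.7-fold higher number from compound 1 to compound 4 (0.23 log units; within the scatter). For compound 4 the estimated value is 12000 nM, with an expected range of 3000 nM to 40000 nM.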

Compound 4, half-maximal inhibitory concentration: 9000 nM
Estimate against measurement, compound 4: 1.3-fold (0.12 log units) above; the measured number falls inside the stated range.
By their numbers in this assay, from the lowest: compounds 2, 1 and 4 (each within the scatter of the next, the first and the last beyond it). At a limit, above all of these: compound 3.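

With the stereocentre at a saturated ring carbon drawn R in place of S, this assay gives a 1.3-fold higher number from compound 1 to compound 4 (0.11 log units; within the scatter). The step can be read as one of configuration alone: the fact that compounds 1 and 4 differ only in the configuration as drawn. Among the compounds shown here, the earlier steps each changed atoms, so only this pair shows that, for this one stereocentre on the shared core, inversion leaves the number within the scatter in this assay.

The compounds shown leave open whether the same inversion would also stay within the scatter with bromo on the chain, as in compound 2, or with isopropyl on the ring, as in compound 3, and what inversion at the other two stereo elements would do. Also open, going by these compounds, is how an amine or a longer chain in place of the ring methyl would read in this assay.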